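Vero cytotoxicity of the shared core: ester to sulfonamide

A few compounds are considered here, and "the series" means these few. Any claim that something is new, unique, unknown or untested is made for them only; others in the source may bear on it.

Measured so far:
Compound 1 `O=C(OC1CCC(CN2CCN(c3cc(=O)c4cc(C(F)(F)F)cc([N+](=O)[O-])c4s3)CC2)CC1)C1CCC1` gives > 64 ug/mL in an ADME assay on Vero cells (Chlorocebus sabaeus) for cytotoxicity, read by MTT assay, with a stated time of 48 h (on this read-out higher numbers stand for weaker inhibition and lower numbers for stronger inhibition), which is a limit of the assay and not a number.
Compound 2 `COc1ccc(C(=O)OC2CCC(CN3CCN(c4cc(=O)c5cc(C(F)(F)F)cc([N+](=O)[O-])c5s4)CC3)CC2)cc1` gives > 64 ug/mL in this assay, again a limit rather than a number.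
Compound 3 `C=CC(=O)OC1CCC(CN2CCN(c3cc(=O)c4cc(C(F)(F)F)cc([N+](=O)[O-])c4s3)CC2)CC1` gives > 64 ug/mL in this assay, once more a limit.

Compound 3 therefore stands at the limit of > 64 ug/mL in this assay, at which 3 of the 3 values shown sit, and nothing in the series separates it from the other two. Among the measured compounds shown here, the three steps between the measured compounds, a step that the two limits leave unreadable from compound 1 to compound 2, a step that the two limits leave unreadable from compound 1 to compound 3 and a step that the two limits leave unreadable from compound 2 to compound 3, are all unreadable, since both ends of each sit at the limit; they show only that swapping the group on the carbonyl carbon among cyclobutyl, 4-methoxyphenyl and vinyl has not brought any compound into the measurable range.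

Compound 4 `O=c1cc(N2CCN(CC3CCC(NS(=O)(=O)c4ccccc4)CC3)CC2)sc2c([N+](=O)[O-])cc(C(F)(F)F)cc12` is the next case. Its change from compound 3 is (phenylsulfonyl)amino in place of (vinylcarbonyl)oxy on a saturated ring carbon. For the measured compounds named here, no measured step bears directly on this replacement, as every step known in this assay involves only the group on the carbonyl carbon of the ester. With all three measured compounds at the limit, the expected step that the limit leaves unreadable from compound 3 to compound 4 is no readable step at all. Compound 4 is therefore estimated at 70 ug/mL, within a range of 40 ug/mL to 150 ug/mL, and most likely it will again be reported only as a limit.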

Compound 4, half-maximal inhibitory concentration: > 64 ug/mL
Compound 4 ended at the assay's limit; the forecaster's own chance of this, stated with the estimate: 85%; the middle value does not contradict the limit.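

Compound 4 gives > 64 ug/mL in this assay, a limit and not a number. Its steps from compound 1, compound 2 and compound 3 therefore cannot be read, as all four compounds share one limit: the limit of > 64 ug/mL in this assay, at which 4 of the 4 values shown sit.

The compounds shown leave open whether (phenylsulfonyl)amino and the ester groups differ at all in this assay, since none has a measurable value.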